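Side-chain notes: from compound 3 to compound 4

The source may hold more compounds than are shown below. What is called first, only, known or untested is meant among the compounds shown, and "the series" means these compounds.

Values in a functional assay on HCT-116 cells (Homo sapiens) for inhibition; a higher number here means a weaker inhibitor, a lower number a stronger inhibitor:
- compound 1 `CCNC(=O)c1noc(-c2cc(C(C)C)c(O)cc2O)c1-c1cc(COCC(=O)OC)no1` gives 262 nM
- compound 2 `CCNC(=O)c1noc(-c2cc(C(C)C)c(O)cc2O)c1-c1cc(COCC(N)=O)no1` gives 97 nM
- compound 3 `C=CNCc1cc(-c2c(C(=O)NCC)noc2-c2cc(C(C)C)c(O)cc2O)on1` gives 121 nM

Compound 3 cannot be separated from compound 2, with a 1.2-fold higher number from compound 2 to compound 3 (0.10 log units; within the scatter). It does lie clear of the number for compound 1, with a 2.2-fold lower number from compound 1 to compound 3 (0.34 log units; beyond the scatter).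

Compound 4 `CCNC(=O)c1noc(-c2cc(C(C)C)c(O)cc2O)c1-c1cc(CNC(C)=O)no1` keeps the core of compound 3 and carries acetyl in place of vinyl on an amine nitrogen. Among the measured compounds shown here, no measured step makes this exact change, so the evidence is indirect. The side-chain changes measured so far are modest at most: a 2.7-fold lower number from compound 1 to compound 2 (0.43 log units; beyond the scatter), and a 2.2-fold lower number from compound 1 to compound 3 (0.34 log units; beyond the scatter). The change from carbamoylmethoxy to vinylamino stays within the scatter, with a 1.2-fold higher number from compound 2 to compound 3 (0.10 log units; within the scatter). On that basis, no shift beyond the scatter is expected in this assay, in either direction. The expected step is a 1.1-fold higher number from compound 3 to compound 4 (0.03 log units; within the scatter). For compound 4 the estimated value is 130 nM, with an expected range of 55 nM to 300 nM.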

Compound 4, half-maximal inhibitory concentration: 167 nM
For compound 4 the middle estimate is 1.3-fold (0.11 log units) below the measured one, within the range that was stated.
By their numbers in this assay, from the lowest: compounds 2, 3, 4 and 1 (each within the scatter of the next, the first and the last beyond it).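

In this assay, acetyl on the amine nitrogen cannot be separated from vinyl (a 1.4-fold higher number from compound 3 to compound 4 (0.14 log units; within the scatter)), so the entering oxygen and hydrogen-bond acceptor leave the number within the scatter. Acetamido on the saturated chain carbon bound to an aromatic carbon also stays within the scatter of carbamoylmethoxy (a 1.7-fold higher number from compound 2 to compound 4 (0.24 log units; within the scatter)) and of (methoxycarbonyl)methoxy (a 1.6-fold lower number from compound 1 to compound 4 (0.20 log units; within the scatter)), even though those two groups stand apart (a 2.7-fold lower number from compound 1 to compound 2 (0.43 log units; beyond the scatter)). No independent evidence bears on this result.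

The compounds shown leave open whether a carboxylic acid or a dimethylamino group at this side-chain position would stay within the same narrow band of numbers. They also leave open whether a longer acyl chain, such as propanoyl, on the amine nitrogen would shift the number in this assay beyond the scatter.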